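This account rests on a few compounds, and the source may have more. Where it says the series, first, only, none or still open, it means among the compounds named here.

Working notes on the series. The compounds share one core, seen in compound 1 `CCCCc1nc(C(C)C)c(CC(=O)OCC(F)(F)F)c(=O)n1Cc1ccc(-c2ccccc2-c2noc(=O)[nH]2)cc1`, compound 2 `CCCCOC(=O)Cc1c(C(C)C)nc(CCCC)n(Cc2ccc(-c3ccccc3-c3noc(=O)[nH]3)cc2)c1=O` and compound 3 `CC#CCOC(=O)Cc1c(C(C)C)nc(CCCC)n(Cc2ccc(-c3ccccc3-c3noc(=O)[nH]3)cc2)c1=O`; they differ in the ester chain. In an ADME assay on microsomes from liver (Mus musculus) for metabolic stability, with a stated time of 30 min (a higher number here means that more of the compound is left, a lower number that less of the compound is left), compound 1 gives "not determined" (no result reported). In this assay compound 2 gives 21.6%, the higher of the two numbers available, and compound 3 gives 16.4%. Going by the values given here, the only measured step, a number 5.2 percentage points lower from compound 2 to compound 3 (within the scatter), lies within the scatter, so the butyl and but-2-ynyl esters cannot be told apart on this read-out.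

Compound 4 `CCCCOC(=O)Cc1c(C)nc(CCCC)n(Cc2ccc(-c3ccccc3-c3noc(=O)[nH]3)cc2)c1=O` is not yet measured. Its change from compound 2 is methyl in place of isopropyl on an aromatic carbon. Among the compounds with values here, no measured step touches this aromatic carbon: the single known step concerns the ester chain and was within the scatter. With nothing that bears on the exchange at the aromatic carbon, the value of compound 2, 21.6%, is the only anchor, and the expected step is a number 0.4 percentage points higher from compound 2 to compound 4 (within the scatter), none beyond the scatter. Compound 4 is therefore estimated at 22% in this assay, within a range from 10% to 40%, the width reflecting the absence of any directly comparable step.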

Compound 4, percent of the compound remaining: 10.2%
Compound 4: the middle estimate sits 11.8 percentage points above what was measured; measured number inside the range.
By their numbers in this assay, from the lowest: compounds 4, 3 and 2 (each within the scatter of the next, the first and the last beyond it).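

Going by these compounds alone, the first step beyond the scatter lies on the aromatic carbon next to the ring nitrogen, not in the ester chain: in this assay, methyl in place of isopropyl, with the butyl ester kept, gives the step (a number 11.4 percentage points lower from compound 2 to compound 4 (beyond the scatter)). Within the data shown here, this position therefore registers on this read-out, whereas the one step in the ester chain, from butyl to but-2-ynyl, could not be told apart from the scatter. Nothing available here accounts for the size or the direction of the step.

Only isopropyl and methyl are shown on this carbon, so it remains open whether an ethyl or a cyclopropyl group would give a number nearer that of compound 2 or that of compound 4, and whether the number follows the count of carbons in the group at all. On these data alone, it is equally open whether the exchange has a similar effect in the but-2-ynyl ester of compound 3 or with another ester chain, such as a longer chain or one carrying an amine.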